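The source may report more compounds than this note shows. Statements on the series, on what has been measured and on what is new or still open speak of the compounds shown alone.

Within the data shown here, in a functional assay on PC-3 cells (Homo sapiens) for antiproliferative activity, read by MTT assay, with a stated time of 72 h (on this read-out lower numbers stand for stronger inhibition and higher numbers for weaker inhibition), compound 2 (`CCCCCCCCCCCCNC[C@@H]1OC[C@H](N)[C@H]1O`) gives 2380 nM, the lowest of the two numbers so far, while compound 1 (`CCCCCCCCNC[C@@H]1OC[C@H](N)[C@@H]1O`) gives 13800 nM. Compound 3 (`CCCCCCCCCNC[C@@H]1OC[C@H](N)[C@H]1O`) shortens the chain of compound 2: hydrogen in place of propyl on a saturated chain carbon, nine bonds along the chain from an amine nitrogen. Among the measured compounds shown here, no measured step isolates this change, so the expectation of weaker inhibition in this assay, beyond the scatter, rests only on the higher number of compound 1 at 13800 nM. The expected change is a 2.9-fold higher number from compound 2 to compound 3 (0.47 log units; beyond the scatter). For compound 3 the estimated value is 7000 nM, within a range of 3000 nM to 18000 nM.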

Compound 3, half-maximal inhibitory concentration: 7650 nM
The estimate for compound 3 lay 1.1-fold (0.04 log units) below the measured number; measured number inside the range.
By their numbers in this assay, from the lowest: compound 2; then compounds 3 and 1 (each within the scatter of the next).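

In this assay, hydrogen in place of propyl on a saturated chain carbon, nine bonds along the chain from an amine nitrogen, gives a 3.2-fold higher number from compound 2 to compound 3 (0.51 log units; beyond the scatter). Among these compounds, this is the first measured step to isolate chain length on the shared core, and it shows that this outer stretch of the chain matters on this read-out, though only modestly. Nothing available explains the step. On these data alone, whether a chain longer than that of compound 2 would lower the number further remains open, as does the effect of an amine or a carboxylic acid at the chain end.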